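The source may report more compounds than this note shows. Statements on the series, on what has been measured and on what is new or still open speak of the compounds shown alone.

Among the compounds with values here, in an ADME assay on microsomes from liver (Homo sapiens) for metabolic stability, with a stated time of 30 min, tested at 1 uM (a higher number here means that more of the compound is left, a lower number that less of the compound is left), compound 2 `CC[C@@H]1C(=O)N(C)c2cnc(-n3ccnc3-c3ccccc3)nc2N1[C@@H]1CCOC1` gives 10%, the lowest of the three numbers so far, and its gap to each of the other two lies beyond the scatter. Compound 1 `CC[C@@H]1C(=O)N(C)c2cnc(-c3cn[nH]c3-c3ccc(F)cc3F)nc2N1c1cnn(C)c1` gives 48% and compound 3 `CC[C@@H]1C(=O)N(C)c2cnc(-n3ccnc3-c3ccc(F)cc3)nc2N1[C@H]1CCOC1` gives 58%, and these two values lie within the scatter of each other. Within the data shown here, no measured pair differs in one place only, so no measured step bears directly on the next comparison.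

Compound 4 `CC[C@@H]1C(=O)N(C)c2cnc(-n3ccnc3-c3ccccc3)nc2N1C1CCCC1`, not yet measured, carries cyclopentyl in place of oxolan-3-yl on a nitrogen on an aromatic ring in a ring, and the rest of compound 2 is unchanged: cyclopentyl in place of oxolan-3-yl on a nitrogen on an aromatic ring in a ring.

Among the measured compounds shown here, with no measured step to lean on, the expectation in this assay is a small downward move or none beyond the scatter. With compound 2 at 10%, little room remains below it. The estimated step is a number 3 percentage points lower from compound 2 to compound 4 (within the scatter), and it is expected to stay within the scatter. For compound 4 the estimated value is 7%, with an expected range from 2% to 20%.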

Compound 4, percent of the compound remaining: 0%
Estimate against measurement, compound 4: 7 percentage points above; the whole stated range lies above it.
By their numbers in this assay, from the lowest: compounds 4 and 2 (each within the scatter of the next); then compounds 1 and 3 (each within the scatter of the next).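

In this assay, within the data shown here, cyclopentyl in place of oxolan-3-yl on a nitrogen on an aromatic ring in a ring gives the first one-place step, a number 10 percentage points lower from compound 2 to compound 4 (within the scatter), so this exchange does not separate the two compounds in this read-out, even though it removes the hydrogen-bond acceptor and the defined stereocentre counted for oxolan-3-yl. At this position, then, the ring oxygen of oxolan-3-yl is not shown to matter for the percent of compound remaining, although compound 2 starts so low in the read-out that a further fall could hardly be resolved. Nothing available bears on why both compounds sit at this level.

The compounds shown leave open whether a group of another kind on this nitrogen, such as a piperidine with its basic amine, a carboxylic acid or a longer alkyl chain, would lift the percent remaining clear of the scatter. Among these compounds, they also leave open whether the stereocentre of oxolan-3-yl counts by itself, since no one-place pair isolates it.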